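Swapping the aryl amine for a cyclopropyl amine

This account rests on a few compounds, and the source may have more. Where it says the series, first, only, none or still open, it means among the compounds named here.

For the measured compounds named here, compound 1 `O=C(CCCCCCn1cc(Nc2ncc(Cl)c(Nc3ccc(F)cc3)n2)cn1)NO` is one of three compounds measured in a functional assay on K562 cells (Homo sapiens) for antiproliferative activity, read by MTT assay, with a stated time of 48 h (on this read-out higher numbers stand for weaker inhibition and lower numbers for stronger inhibition), where compound 1 gives 500 nM. Compound 2 `O=C(CCCCCCn1cc(Nc2ncc(C(F)(F)F)c(Nc3ccc(F)cc3)n2)cn1)NO` gives 480 nM and compound 3 `O=C(CCCCCn1cc(Nc2ncc(Cl)c(Nc3ccc(F)cc3)n2)cn1)NO` gives 420 nM, so all three sit close together: the step of a 1.0-fold lower number from compound 1 to compound 2 (0.02 log units; within the scatter) and the step of a 1.2-fold lower number from compound 1 to compound 3 (0.08 log units; within the scatter) both fall within the scatter. Compound 4 `O=C(CCCCCCn1cc(Nc2ncc(Cl)c(NC3CC3)n2)cn1)NO` has not yet been measured. It differs from compound 1 in one place: cyclopropyl in place of 4-fluorophenyl on a nitrogen on an aromatic ring. Neither measured step bears on this change. The step from compound 1 to compound 2 alters the group on an aromatic carbon, and the step from compound 1 to compound 3 shortens the chain; both leave the (4-fluorophenyl)amino untouched, and both are small. The data therefore give no direct guide, and the change is larger than either of those tested, so a step beyond the scatter toward a higher number is expected for compound 4, a 4.0-fold higher number from compound 1 to compound 4 (0.60 log units; beyond the scatter). Compound 4 is estimated at 2000 nM, within a range from 600 nM to 7000 nM.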

Compound 4, half-maximal inhibitory concentration: 380 nM
Compound 4: the middle estimate sits 5.3-fold (0.72 log units) above what was measured, and the stated range ends above it.
By their numbers in this assay, from the lowest: compounds 4, 3, 2 and 1 (each within the scatter of the next).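

Compound 1 and the other earlier compounds all carry 4-fluorophenyl on this nitrogen on an aromatic ring, so they could not show whether that aromatic ring matters here. In this assay, cyclopropyl in place of 4-fluorophenyl gives a 1.3-fold lower number from compound 1 to compound 4 (0.12 log units; within the scatter) and so leaves the reading indistinguishable, even though the entering group has 3 heavy atoms against 7 and a three-membered non-aromatic ring in place of a six-membered aromatic one. For this pair, then, the aromatic ring at this place is not needed to keep the reading, but nothing available explains why the two groups read alike.

From the compounds shown here alone, it remains open whether other groups on this nitrogen, such as methyl, cyclohexyl or a 2-hydroxyethyl chain, would also match in this assay. Going by these compounds, it is also open whether cyclopropylamino would keep this reading alongside trifluoromethyl in place of chloro or with the chain of compound 3.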